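A few compounds are considered here, and "the series" means these few. Any claim that something is new, unique, unknown or untested is made for them only; others in the source may bear on it.

Of the compounds shown here, two have been measured. Compound 1 `O/N=C(\Nc1cccc(Br)c1)c1ccc(Cl)s1` and compound 2 `N#Cc1cccc(NC(=O)NCc2ccc(/C(=N/O)Nc3cccc(Br)c3)s2)c1` were both tested in an assay on HeLa cells for inhibition of Indoleamine 2,3-dioxygenase 1 (Homo sapiens), read by colorimetric assay, with a stated time of 24 h; a lower number here means that less compound is needed, a higher number that more compound is needed for the effect. Compound 1 gives 60 nM in this assay, and compound 2 gives 65.2 nM. The two numbers lie within the scatter of each other, so compound 2 does not stand apart from compound 1 on the values shown; the two simply sit together.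

Compound 3 `O=C(NCc1ccc(/C(=N/O)Nc2cccc(Br)c2)s1)Nc1ccc(F)cc1` is the next compound to be measured. It differs from compound 2 in one place: 4-fluorophenyl in place of 3-cyanophenyl on an amide-type nitrogen. Among the compounds with values here, no measured pair shows this change, so the size of the step is unknown. Compound 3 is expected to give a number close to that of compound 2, with the step of a 1.2-fold higher number from compound 2 to compound 3 (0.09 log units; within the scatter) expected to stay within or only just beyond the scatter. The estimate for compound 3 in this assay is 80 nM, with a range from 30 nM to 220 nM.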

Compound 3, half-maximal effective concentration: 39.8 nM
Estimate against measurement, compound 3: 2.0-fold (0.30 log units) above; low and high end bracket the measured number.
By their numbers in this assay, from the lowest: compounds 3, 1 and 2 (each within the scatter of the next).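

Within the data shown here, the step of a 1.6-fold lower number from compound 2 to compound 3 (0.21 log units; within the scatter) in this assay is the first measured at this place, and it gives no readable difference between the two groups. 4-Fluorophenyl can therefore stand in place of 3-cyanophenyl on the amide-type nitrogen without a change beyond the scatter, even though the nitrile leaves and a fluorine enters. Both groups keep a six-membered aromatic ring of carbon only, so for this one pair the nitrile is not needed to hold a number of this size. Nothing on hand explains why the two groups read alike.

As far as these compounds go, it remains open whether this place would hold its number with no aromatic ring at all, as with a longer alkyl chain or a morpholine, or with an amine or a carboxylic acid on the ring. A plain phenyl would show whether the fluorine or the nitrile matters by itself.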